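A few compounds are considered here, and "the series" means these few. Any claim that something is new, unique, unknown or untested is made for them only; others in the source may bear on it.

Measured so far in a functional assay on MDA-MB-231 cells (Homo sapiens) for cytotoxicity, read by MTT assay, with a stated time of 48 h; a lower number here means a stronger inhibitor, a higher number a weaker inhibitor:
compound 1 `O=C(/C=C/c1ccc2c(c1)B(O)OC2)c1ccco1` — 7300 nM
compound 2 `O=C(/C=C/c1ccc2c(c1)B(O)OC2)c1ccc(I)cc1` — 14900 nM
compound 3 `O=C(/C=C/c1ccc2c(c1)B(O)OC2)c1ccc(OCc2ccccc2)cc1` — 5300 nM

Compound 2 gives the highest number of the three in this assay: the nearest is compound 1, which lies a 2.0-fold higher number from compound 1 to compound 2 (0.31 log units; beyond the scatter) in the other direction, and the furthest is compound 3, reached by a 2.8-fold lower number from compound 2 to compound 3 (0.45 log units; beyond the scatter). Both steps are beyond the scatter, so compound 2 is the weakest of the three measured.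

The next compound, compound 4 `O=C(/C=C/c1ccc2c(c1)B(O)OC2)c1ccccc1O`, is not yet measured. It differs from compound 2 by 2-hydroxyphenyl in place of 4-iodophenyl on a carbonyl carbon.

Going by the values given here, two measured steps bear on this change, both of them alterations of the group on the carbonyl carbon: a 2.0-fold higher number from compound 1 to compound 2 (0.31 log units; beyond the scatter) and a 2.8-fold lower number from compound 2 to compound 3 (0.45 log units; beyond the scatter). Among the compounds with values here, each is modest in size, and the only step from compound 2 that is known, the one to compound 3, went downward. Within the data shown here, a change of the aryl group of comparable size in this assay is therefore expected, most likely downward, though no measured step places a hydroxyl on that ring.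

For compound 4 the estimate in this assay is 7000 nM, in the range 2500 nM to 20000 nM, which would be an expected step of a 2.1-fold lower number from compound 2 to compound 4 (0.33 log units; beyond the scatter).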

Compound 4, half-maximal inhibitory concentration: 16900 nM
For compound 4 the middle estimate is 2.4-fold (0.38 log units) below the measured one; the range from low to high includes it.
By their numbers in this assay, from the lowest: compounds 3 and 1 (each within the scatter of the next); then compounds 2 and 4 (each within the scatter of the next).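

In this assay, a 1.1-fold higher number from compound 2 to compound 4 (0.05 log units; within the scatter), so this exchange on the carbonyl carbon gives no readable difference, even though the 2-hydroxyphenyl group carries a hydrogen-bond donor and acceptor that the 4-iodophenyl group lacks. The second new step, a 2.3-fold higher number from compound 1 to compound 4 (0.36 log units; beyond the scatter), shows that furan-2-yl gives a lower number than 2-hydroxyphenyl as well as 4-iodophenyl, although this does not extend to every substituted phenyl group: compound 3, with its benzyloxy substituent, goes against it at 5300 nM. No measurement available here accounts for the match between compound 2 and compound 4 or for the separation of both from compound 1.

Compound 2 and compound 4 differ in both the substituent and its place on the ring, so the two contributions remain unseparated, and a single matched pair cannot show whether the hydroxyl or the iodine alone matters. Also open, from the compounds shown here alone, is how an amine, a carboxylic acid or a longer alkoxy chain on this aryl ring would read in this assay, and whether a ring such as thiophene would track with furan-2-yl.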